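Cyclopentyl ether in place of an ethoxyethyl chain

A few compounds are considered here, and "the series" means these few. Any claim that something is new, unique, unknown or untested is made for them only; others in the source may bear on it.

Measured so far:
compound 1 `Nc1ccc2cccc(OCCC3CCCCC3)c2n1` gives 808 nM
compound 2 `CCOCCOc1cccc2ccc(N)nc12` gives only a limit, > 2000 nM
compound 3 `CC1CCCC(Oc2cccc3ccc(N)nc23)C1` gives 640 nM

In an assay on cells with melanin-concentrating hormone receptor 1 (Homo sapiens) as the target, read by radioligand binding (on this read-out lower numbers stand for stronger inhibition and higher numbers for weaker inhibition), compound 1 gives 808 nM and compound 3 gives 640 nM. For compound 2 no number is known, only the limit > 2000 nM. Compound 2 therefore stands at the weak end of the measured set, at the limit of > 2000 nM in this assay, at which 1 of the 3 values shown sits, and how far beyond that limit it lies is not known.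

Compound 4 `Nc1ccc2cccc(OC3CCCC3)c2n1` differs from compound 2 by cyclopentyl in place of 2-ethoxyethyl on an oxygen on an aromatic ring. Among the compounds with values here, the only measured step that bears on this is an at least 2.4-fold higher number from compound 1 to compound 2 (0.39 log units; beyond the scatter): there, bringing an oxygen-containing chain in for a carbocycle lost binding. The change from compound 2 to compound 4 runs the other way, returning a carbocycle, here cyclopentyl, on an oxygen on an aromatic ring. Compound 3 also carries a carbocycle on an oxygen on an aromatic ring and gives 640 nM, and compound 1 with its cyclohexyl gives 808 nM. A gain beyond the scatter is therefore expected.

Compound 4 is expected to give about 750 nM, with a likely range of 300 nM to 2000 nM. This estimate amounts to a step of an at least 2.6-fold lower number from compound 2 to compound 4 (0.42 log units; beyond the scatter).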

Compound 4, half-maximal inhibitory concentration: > 2000 nM
Compound 4: no number, only a limit (the forecaster's own chance of this, stated with the estimate: 15%); middle value at least 2.6-fold (0.42 log units) away from the limit.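

Compound 2 and compound 4 both stand only as limits, not numbers, so the step between them cannot be read. The compounds shown leave open how far past the limit each lies, and whether cyclopentyl in place of 2-ethoxyethyl changes binding at all.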